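A few compounds are considered here, and "the series" means these few. Any claim that something is new, unique, unknown or untested is made for them only; others in the source may bear on it.

Measured compounds:
Compound 1, `Cc1ccnc(N2C(=O)CS[C@H]2c2cccc(C(=O)NCCCCn3cccn3)c2)c1`: "nd" (no result reported) in a functional assay on MG-63 cells (Homo sapiens) for inhibition, read by CCK-8 assay, with a stated time of 72 h; a lower number here means a stronger inhibitor, a higher number a weaker inhibitor.
Compound 2, `Cc1ccnc(N2C(=O)CSC2c2cccc(C(=O)NCCCCn3cccn3)c2)c1`: 38.9 nM in this assay.

Going by the values given here, compound 2 therefore stands alone on the numbers: it carries the only value reported, and compound 1, which shares all atoms and bonds with it, was not given a number. The one thing that sets the two apart is the fact that one of compounds 1 and 2 is drawn with a defined configuration and the other without, at the place where they differ, so compound 1 is one single mirror-image form while compound 2 is drawn with no configuration at that ring carbon, which usually means a mixture of both forms.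

Compound 3, `Cc1ccnc(N2C(=O)CS[C@@H]2c2cccc(C(=O)NCCCCn3cccn3)c2)c1`, is the other single form. Compared with compound 2, (the two compounds have the same atoms and bonds; at least one stereo element is drawn with a configuration in one of them and without one in the other: 1 of 1 stereo elements differ; a stereocentre at a saturated ring carbon is drawn without a configuration in compound 2 and R in compound 3). A mixture measured as one sample normally reads somewhere between its two components, so a single form may come out a little stronger or a little weaker than the mixture, and the size of that shift cannot be read from the present data. Compound 3 is expected to sit close to compound 2, with the step of a 1.1-fold lower number from compound 2 to compound 3 (0.05 log units; within the scatter) expected to lie within the usual scatter in this assay. The estimate for compound 3 in this assay is 35 nM, with a range from 10 nM to 200 nM.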

Compound 3, half-maximal inhibitory concentration: 14.9 nM
Compound 3: the middle estimate sits 2.3-fold (0.37 log units) above what was measured; the range from low to high includes it.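

Going by these compounds alone, for the first time there is a comparison at this ring carbon, and it shows that the configuration drawn there counts in this assay: the R form gives a 2.6-fold lower number from compound 2 to compound 3 (0.42 log units; beyond the scatter), a modest step, but one larger than repeat measurements would normally produce. No atom or bond changes in this step, so the shift cannot be credited to any group, and the only thing separating the two entries is stereochemistry: the fact that one of compounds 2 and 3 is drawn with a defined configuration and the other without, at the place where they differ Since a compound drawn without a configuration usually means a mixture of both forms, a single form that reads stronger than the mixture suggests that the two forms do not contribute equally, with the R form likely the more active one.

Going by these compounds, the other single form, compound 1, shows "nd" (no result reported), so the direct comparison of the two mirror-image forms cannot be read and the true gap between them stays unknown: the fact that compounds 1 and 3 differ only in the configuration as drawn Whether the R form would keep its edge with a longer chain or an amine elsewhere on the shared core also stays open.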